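Replacing the Hydroxy by Chloro on the Aryl Ketone

The source may hold more compounds than are shown below. What is called first, only, known or untested is meant among the compounds shown, and "the series" means these compounds.

Compound 2 `O=C(/C=C/c1cc2ccccc2[nH]c1=O)c1ccc(O)cc1` gives 9300 nM in a functional assay on SNB-75 cells (Homo sapiens) for cytotoxicity, read by sulforhodamine B assay, with a stated time of 24 h (a lower number here means a stronger inhibitor of growth, a higher number a weaker inhibitor of growth), and stands at the higher of the two numbers measured, beyond the scatter from its nearest neighbour. That neighbour, compound 1 `COc1ccc(C(=O)/C=C/c2cc3ccccc3[nH]c2=O)cc1`, gives 2290 nM in this assay. Going by the values given here, the single measured step, a 4.1-fold higher number from compound 1 to compound 2 (0.61 log units; beyond the scatter), is the only guide available.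

Compound 3 `O=C(/C=C/c1cc2ccccc2[nH]c1=O)c1ccc(Cl)cc1` keeps the shared core and differs from compound 2 by chloro in place of hydroxy on an aromatic carbon. Among the compounds with values here, no measured step covers this exact exchange. Because a 4.1-fold higher number from compound 1 to compound 2 (0.61 log units; beyond the scatter) showed that uncovering the hydroxy raised the number, and compound 3 has no hydroxy at that place at all, the number for compound 3 is expected to fall back towards that of compound 1 rather than rise further. Compound 3 is therefore estimated to move by a 3.7-fold lower number from compound 2 to compound 3 (0.57 log units; beyond the scatter). Compound 3 is estimated at 2500 nM, with a likely range from 800 nM to 8000 nM.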

Compound 3, concentration for 50% growth inhibition: 6210 nM
Beside the measured number, compound 3's estimate is 2.5-fold (0.40 log units) below it; the range from low to high includes it.
By their numbers in this assay, from the lowest: compound 1; then compounds 3 and 2 (each within the scatter of the next).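

In this assay, chloro in place of hydroxy on this aromatic carbon gives a 1.5-fold lower number from compound 2 to compound 3 (0.18 log units; within the scatter) so these two groups cannot be told apart here, although chloro has no hydrogen-bond donor or acceptor and hydroxy has both. Compound 1 remains set apart, and chloro in place of its methoxy gives a 2.7-fold higher number from compound 1 to compound 3 (0.43 log units; beyond the scatter) so losing the hydroxy hydrogen is not enough on its own to bring the number down to that of compound 1. No measured evidence is at hand to explain these numbers.

Going by these compounds, it remains open how an amine or a carboxylic acid would behave at this place on the ring. A longer chain on the oxygen than the methyl of compound 1 is also untested among the compounds shown here.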